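Predicting a dimethoxyphenyl analogue from two measured compounds

The source may hold more compounds than are shown below. What is called first, only, known or untested is meant among the compounds shown, and "the series" means these compounds.

Compound 1 and compound 2, built on a shared core, have been measured in a functional assay, with a stated time of 150 min; on this read-out lower numbers stand for stronger inhibition and higher numbers for weaker inhibition. Compound 1 `CCOC(=O)c1cnn(-c2nc(-c3ccc(OC)cc3)c(C#N)c(=O)n2C)c1N` carries a 4-methoxyphenyl group, and in this assay compound 1 gives 79 ug/mL. Compound 2 `CCOC(=O)c1cnn(-c2nc(-c3ccccc3F)c(C#N)c(=O)n2C)c1N` carries a 2-fluorophenyl group in its place, and in this assay compound 2 gives 87 ug/mL. Going by the values given here, on the numbers so far compound 2 stands alongside compound 1: the step of a 1.1-fold higher number from compound 1 to compound 2 (0.04 log units; within the scatter) falls within the scatter, so the two readings cannot be told apart.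

Compound 3 `CCOC(=O)c1cnn(-c2nc(-c3cccc(OC)c3OC)c(C#N)c(=O)n2C)c1N` has not yet been measured. It differs from compound 2 by 2,3-dimethoxyphenyl in place of 2-fluorophenyl on an aromatic carbon. Among the compounds with values here, the only measured step that bears on this, an exchange of the aryl group on the aromatic carbon, was a 1.1-fold higher number from compound 1 to compound 2 (0.04 log units; within the scatter), too small to set a direction. With nothing further to draw on, the step expected here is a 1.1-fold lower number from compound 2 to compound 3 (0.04 log units; within the scatter), none beyond the scatter. Compound 3 is therefore estimated to give 80 ug/mL in this assay, with a range from 40 ug/mL to 160 ug/mL.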

Compound 3, half-maximal inhibitory concentration: 69 ug/mL
Beside the measured number, compound 3's estimate is 1.2-fold (0.06 log units) above it; the measured number falls inside the stated range.
By their numbers in this assay, from the lowest: compounds 3, 1 and 2 (each within the scatter of the next).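

With a third aryl group now on this aromatic carbon, the exchange of 2-fluorophenyl for 2,3-dimethoxyphenyl gives a 1.3-fold lower number from compound 2 to compound 3 (0.10 log units; within the scatter) in this assay, and the exchange of 4-methoxyphenyl for 2,3-dimethoxyphenyl gives a 1.1-fold lower number from compound 1 to compound 3 (0.06 log units; within the scatter). Going from the 7 heavy atoms and 0 hydrogen-bond acceptors of 2-fluorophenyl to the 10 heavy atoms and 2 hydrogen-bond acceptors of 2,3-dimethoxyphenyl therefore leaves the read-out within the scatter, so these three aryl groups cannot be ranked and a clearly larger exchange than the first one still sets no direction at this position. No measurement is available that would account for this lack of separation among the three compounds.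

Going by these compounds, all three compounds carry an aryl group here, so it remains open whether an amine, a carboxylic acid or a longer alkyl chain on this carbon would move the number in this assay beyond the scatter. The compounds shown also all keep the same ethyl ester, nitrile and methyl group on the shared core, which leaves the contribution of those groups open.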